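Methoxy Next to the Indole-Linked Core: A Small Expected Shift

The source may report more compounds than this note shows. Statements on the series, on what has been measured and on what is new or still open speak of the compounds shown alone.

Compound 1 `Nn1c(SCc2ccccc2)nnc1-c1c[nH]c2ccccc12` is a modest inhibitor in a functional assay on KG-1a cells (Homo sapiens) for cytotoxicity, with a stated time of 24 h (on this read-out higher numbers stand for weaker inhibition and lower numbers for stronger inhibition), where compound 1 gives 17200 nM. Within the data shown here, its one measured partner is compound 2 `Nn1c(SCc2ccc([N+](=O)[O-])cc2)nnc1-c1c[nH]c2ccccc12`, which carries a nitro group where compound 1 has none; in this assay compound 2 gives 6900 nM. That change produced a 2.5-fold lower number from compound 1 to compound 2 (0.40 log units; beyond the scatter). Among the two numbers so far, compound 1 therefore stands highest.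

Compound 3 `COc1ccc(CSc2nnc(-c3c[nH]c4ccccc34)n2N)cc1` is not yet measured. Compared with compound 1, the change is methoxy in place of hydrogen on an aromatic carbon. Among the measured compounds shown here, the only measured step that bears on this is the nitro step, which was modest in size and lowered the number. For the measured compounds named here, a methoxy group is a different substituent from nitro, and no measured pair shows what methoxy does here, so a step in this assay of about the same size or smaller is expected, if any, in the lowering direction. Compound 3 is estimated to give about 12000 nM, with a range from 5000 nM to 30000 nM. That expected step is a 1.4-fold lower number from compound 1 to compound 3 (0.16 log units; within the scatter).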

Compound 3, half-maximal inhibitory concentration: > 100000 nM
Compound 3 gave a limit, no number (the forecaster's own chance of this, stated with the estimate: 10%); middle value at least 8.3-fold (0.92 log units) away from the limit.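

In this assay, the position para to a large group proves sensitive in both directions, since nitro in place of hydrogen gave a 2.5-fold lower number from compound 1 to compound 2 (0.40 log units; beyond the scatter), whereas methoxy in place of hydrogen gave an at least 5.8-fold higher number from compound 1 to compound 3 (0.76 log units; beyond the scatter). The two groups therefore pull the number apart at this single place, and methoxy in place of nitro gave an at least 14-fold higher number from compound 2 to compound 3 (1.16 log units; beyond the scatter), so adding a group of only 2 heavy atoms here can be enough to move the read-out well beyond the scatter, and upward rather than downward. The result for compound 3 is a limit of the assay and not a number, so both steps give only a minimum size: the limit of > 100000 nM in this assay, at which 1 of the 3 values shown sits.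

As far as these compounds go, with just hydrogen, nitro and methoxy at this position, it remains open whether the upward step belongs to methoxy alone or would also appear with other groups, such as a hydroxyl, an amine, a chlorine or a longer chain like ethoxy. From the compounds shown here alone, it is also open how far the number of compound 3 lies past the limit, and whether methoxy would act the same way elsewhere on the ring.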